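A few compounds are considered here, and "the series" means these few. Any claim that something is new, unique, unknown or untested is made for them only; others in the source may bear on it.

Compound 1 `Cc1ccc2c(NCc3ccc(NC(=O)C4CCN(Cc5ccc(Cl)cc5)CC4)cc3)nc(N(C)C)nc2c1`: > 3180 nM
Compound 2 `Cc1ccc2c(NCc3ccc(NC(=O)C4CCN(Cc5ccccc5)CC4)cc3)nc(N3CCC(N4CCCC4)CC3)nc2c1`: > 8090 nM

In a functional assay on SV5A8 cells (Homo sapiens) for cytotoxicity (on this read-out lower numbers stand for stronger inhibition and higher numbers for weaker inhibition), compound 1 gives only a limit, > 3180 nM, so no number marks where it truly stands. Compound 2 likewise gives only a limit in this assay, > 8090 nM. Both values shown are therefore limits, as the limit of > 3180 nM in this assay, at which 1 of the 2 values shown sits, and the limit of > 8090 nM in this assay, at which 1 of the 2 values shown sits, record, and neither shows a compound with measurable activity in this assay.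

Compound 3 `Cc1ccc2c(NCc3ccc(NC(=O)C4CCN(C)CC4)cc3)nc(N(C)C)nc2c1` is the unmeasured partner of compound 1. The difference between the two is hydrogen in place of 4-chlorophenyl on a saturated chain carbon bound to an amine nitrogen in a ring. Among the measured compounds shown here, no pair of measured compounds shows what such a change does in this assay, so its effect is not known from these data. Given that compound 1 sits at a limit, (the limit of > 3180 nM in this assay, at which 1 of the 2 values shown sits), the expected step from compound 1 to compound 3 in this assay is none beyond the scatter, with compound 3 also expected to remain without measurable activity, which means an expected change of a step that the limit leaves unreadable from compound 1 to compound 3. Compound 3 is therefore estimated at 8000 nM in this assay, within a range from 2000 nM to 40000 nM, and most likely reported as a limit only.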

Compound 3, half-maximal inhibitory concentration: > 17300 nM
Compound 3 gave a limit, no number (the forecaster's own chance of this, stated with the estimate: 75%); middle value at least 2.1-fold (0.33 log units) from the limit.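

In this assay compound 3 gives only a limit, > 17300 nM. Compound 1 also gives only a limit, so the step between compound 1 and compound 3 cannot be read. The compounds shown leave open what 4-chlorobenzyl to methyl does to the read-out, and at what concentration, if any, any of them acts in this assay.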